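Third Methoxy on a Fluoro Benzothiazole Amide

A few compounds are considered here, and "the series" means these few. Any claim that something is new, unique, unknown or untested is made for them only; others in the source may bear on it.

The measured compounds, all read in a functional assay on A549 cells (Homo sapiens) for cytotoxicity, read by MTT assay, with a stated time of 48 h (on this read-out lower numbers stand for stronger inhibition and higher numbers for weaker inhibition), are these:
compound 1 `COc1cc(-c2cc(C(=O)Nc3nc4ccc(Cl)cc4s3)nc3cc(-c4ccccc4)nn23)cc(OC)c1OC` with 18200 nM;
compound 2 `COc1ccc(-c2cc(C(=O)Nc3nc4ccc(F)cc4s3)nc3cc(-c4ccccc4)nn23)cc1` with 11700 nM;
compound 3 `COc1ccc(-c2cc(C(=O)Nc3nc4ccc(F)cc4s3)nc3cc(-c4ccccc4)nn23)cc1OC` with 6910 nM.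

Compound 3 gives the lowest of the three numbers in this assay. Its nearest neighbour is compound 2, whose number is higher, though the two fall within the usual scatter of each other. Compound 1 sits further off, with a number beyond the scatter from that of compound 3; it differs from compound 3 in two places, so only the two values themselves can be compared.

Compound 4 `COc1cc(-c2cc(C(=O)Nc3nc4ccc(F)cc4s3)nc3cc(-c4ccccc4)nn23)cc(OC)c1OC` has not been measured. It differs from compound 3 by methoxy in place of hydrogen on an aromatic carbon.

Within the data shown here, the one measured step that bears on this change is a 1.7-fold lower number from compound 2 to compound 3 (0.23 log units; within the scatter), which added a methoxy group to the same ring and stayed within the scatter. Compound 1, which carries the same three methoxy groups but a chloro atom in place of the fluoro, gives a higher number than compound 3. Taken together, no step beyond the scatter is expected from compound 3 to compound 4 in this assay, though a modest rise remains possible. Compound 4 is therefore estimated at 9000 nM, with a likely range from 3000 nM to 27000 nM, meaning an expected step of a 1.3-fold higher number from compound 3 to compound 4 (0.11 log units; within the scatter).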

Compound 4, half-maximal inhibitory concentration: 22400 nM
Compound 4: middle estimate off by 2.5-fold (0.40 log units), on the low side; the measured number falls inside the stated range.
By their numbers in this assay, from the lowest: compounds 3, 2, 1 and 4 (each within the scatter of the next, the first and the last beyond it).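

In this assay, methoxy in place of hydrogen, ortho to one methoxy group and meta to another, turns 3,4-dimethoxyphenyl into 3,4,5-trimethoxyphenyl and gives a 3.2-fold higher number from compound 3 to compound 4 (0.51 log units; beyond the scatter), whereas the earlier methoxy addition on this ring gave only a 1.7-fold lower number from compound 2 to compound 3 (0.23 log units; within the scatter). The same ring change is therefore not neutral at every position, yet the whole replacement of 4-methoxyphenyl by 3,4,5-trimethoxyphenyl amounts to a 1.9-fold higher number from compound 2 to compound 4 (0.28 log units; within the scatter), so the step beyond the scatter appears only when compound 3 is the point of comparison. With the 3,4,5-trimethoxyphenyl group held constant, fluoro in place of chloro gives a 1.2-fold higher number from compound 1 to compound 4 (0.09 log units; within the scatter), so the halogen makes no difference beyond the scatter on this ring.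

Nothing shown here gives a reason for the response at this position.

It remains open whether a hydroxyl, an amine or an ethoxy group at this same position would follow methoxy, and whether a 3,5-dimethoxyphenyl ring, lacking the methoxy group of 4-methoxyphenyl, would stay within the scatter of these compounds.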